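The source may hold more compounds than are shown below. What is called first, only, known or untested is meant among the compounds shown, and "the series" means these compounds.

Working notes on the series. Among the measured compounds shown here, in a functional assay (aorta) with Rattus norvegicus as the target (a lower number here means a stronger inhibitor, a higher number a weaker inhibitor), compound 1 (`CC(C)c1cn2ccccc2c1S(=O)(=O)c1ccc(OCCCNCc2ccccc2)cc1`) gives 22.8 nM and holds the lowest of the three numbers so far. Compound 3 (`CCCN(CCC)CCCOc1ccc(S(=O)(=O)c2c(C)cn3ccccc23)cc1`) gives 957 nM in this assay and compound 2 (`CCCCCCCCN(CCCCCCCC)CCCOc1ccc(S(=O)(=O)c2c(C(C)C)cn3ccccc23)cc1`) gives 30100 nM there, both beyond the scatter from compound 1. For the measured compounds named here, each of these differs from compound 1 in more than one place, so no measured pair isolates a single change.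

The next compound is compound 4 (`CC(C)c1cn2ccccc2c1S(=O)(=O)c1ccc(OCCCN(C)C)cc1`), with dimethylamino in place of benzylamino on a saturated chain carbon, three bonds along the chain from an oxygen on an aromatic ring. Going by the values given here, no measured step covers this change, so the expectation is indirect. Compound 3 at 957 nM carries dipropylamino and compound 2 at 30100 nM carries dioctylamino, and both sit on higher numbers than compound 1 does. Their other differences keep this reading loose.

A move toward a higher number, meaning a weaker inhibitor, is expected, with the size estimated as an 8.8-fold higher number from compound 1 to compound 4 (0.94 log units; beyond the scatter) and lying beyond the scatter. The estimated value for compound 4 is 200 nM with an expected range from 50 nM to 800 nM in this assay.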

Compound 4, half-maximal inhibitory concentration: 390 nM
Beside the measured number, compound 4's estimate is 2.0-fold (0.29 log units) below it; low and high end bracket the measured number.
By their numbers in this assay, from the lowest: compound 1; then compound 4; then compound 3; then compound 2.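

Compound pairs in this series had not isolated a single change until now: in this assay dimethylamino in place of benzylamino on a saturated chain carbon, three bonds along the chain from an oxygen on an aromatic ring, gives a large step (a 17-fold higher number from compound 1 to compound 4 (1.23 log units; beyond the scatter)). The group on this chain carbon therefore moves the number well beyond the scatter with the rest of the structure held fixed, and benzylamino is the group on the lower number of this pair. The change removes a six-membered aromatic ring of carbon only and a hydrogen-bond donor together, and no measurement shown explains the step.

Open, from the compounds shown here alone, is whether the aromatic ring or the amine hydrogen accounts for the step; methylamino and N-methylbenzylamino at the same place would separate the two. Also open, going by these compounds, is whether 2-phenylethylamino, with a longer link to the ring, or a shorter or longer chain from the oxygen to the amine would keep the lower number of compound 1.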